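Methoxy analogue of the hydroxyphenyl thiazolidinone series

The source may hold more compounds than are shown below. What is called first, only, known or untested is meant among the compounds shown, and "the series" means these compounds.

Measured so far:
- compound 1 `O=C1CSC(c2cccc(O)c2)N1CCN1CCCCC1` gives 100% in an ADME assay on Vero cells (Chlorocebus sabaeus) for cytotoxicity, read by neutral red uptake, tested at 12.3 ug/mL; a lower number here means a stronger effect, a higher number a weaker effect of the compound at the concentration tested
- compound 2 `O=C1CSC(c2ccc(O)cc2)N1CCN1CCCCC1` gives 100% in this assay
- compound 3 `O=C1CSC(c2ccc(F)cc2)N1CCN1CCCCC1` gives 100% in this assay

Compound 1 stands level with compound 2 and compound 3 in this assay; every value sits at the top of the scale, and none of the three compounds can be called the stronger or weaker. The step of no change at the digits printed from compound 1 to compound 2 (within the scatter) and the step of no change at the digits printed from compound 1 to compound 3 (within the scatter) both fall within the scatter, as does no change at the digits printed from compound 2 to compound 3 (within the scatter); exchanging the group on the phenyl ring, or moving it, has so far left the read-out untouched.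

Compound 4 `COc1cccc(C2SCC(=O)N2CCN2CCCCC2)c1` has not been measured. It differs from compound 1 by methyl in place of hydrogen on an oxygen on an aromatic ring. The two steps that bear on it are the ones from compound 1 to compound 2 and from compound 1 to compound 3, both flat, so the step to compound 4 is expected to be no change beyond the scatter, no change at the digits printed from compound 1 to compound 4 (within the scatter). The estimate for compound 4 is therefore 100%, with a range from 88% to 100%.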

Compound 4, a percentage reported as activity, at one concentration (the size of the read-out at that concentration, not a potency): 100%
Compound 4: the middle estimate sits on the measured number at the digits printed; low and high end bracket the measured number.
By their numbers in this assay, from the lowest: compounds 1, 2, 3 and 4 (each within the scatter of the next).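

In this assay, hydroxy to methoxy gives no change at the digits printed from compound 1 to compound 4 (within the scatter). The earlier compounds shown here covered moving the hydroxy group and exchanging the aromatic group for fluoro; this step adds a change on the oxygen itself, where methyl in place of hydrogen leaves the read-out at the printed digits, so the free hydroxy group is not needed to keep that read-out in compound 4. No available evidence bears on this result.

From the compounds shown here alone, whether a longer chain on that oxygen, such as butoxy, or a carboxylic acid or an amine on the aromatic ring would also leave the read-out where it stands remains open. Going by these compounds, all four compounds share the rest of the core, so the effect of changes there is also open.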